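Arginine-to-methionine side-chain swap in an orally dosed series

This account rests on a few compounds, and the source may have more. Where it says the series, first, only, none or still open, it means among the compounds named here.

Two compounds of this series have numbers in a functional assay on the whole organism (Tail, strain ICR) with Mus musculus as the target, in the tail flick test, with a stated time of 150 min, at a dose of 25 umol/kg by the oral route; a lower number here means a weaker effect, a higher number a stronger effect of the compound at the dose given. Compound 1 `N=C(N)NCCC[C@H](NC(=O)CN(c1nc(Cl)nc2[nH]cnc12)C1CC1)C(=O)O` gives 7.19% and stands lowest of the two, though its nearest neighbour, compound 2 `CC(C)(C)OC(=O)NCCCC[C@H](NC(=O)CN(c1ncnc2c1ncn2C1CCCCO1)C1CC1)C(=O)OCc1ccccc1`, gives 17.2%, a number that lies within the scatter of compound 1, so no order between them can be drawn. Both read-outs are small at the dose used.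

Compound 3 `CSCC[C@H](NC(=O)CN(c1nc(Cl)nc2[nH]cnc12)C1CC1)C(=O)O` differs from compound 1 in one place: a group of 2 heavy atoms (1 carbon, 1 sulfur; no ring) in place of a group of 5 heavy atoms (2 carbon, 3 nitrogen; no ring), on a saturated chain carbon, three bonds along the chain from an amide-type nitrogen and a carbonyl carbon. Among the compounds with values here, the change sits on a saturated chain carbon, three bonds along the chain from an amide-type nitrogen and a carbonyl carbon, and no measured pair shows what such an exchange does in this assay. With both known numbers small and close to each other, and nothing to suggest a gain, the expected step from compound 1 to compound 3 in this assay is a number 2.8 percentage points higher from compound 1 to compound 3 (within the scatter), no larger than the scatter in either direction.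

Compound 3 is therefore estimated at 10% in this assay, with a likely range from 0% to 28%.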

Compound 3, a percentage reported as activity, at one dose (the size of the read-out at that dose, not a potency): 4.14%
Compound 3: the middle estimate sits 5.9 percentage points above what was measured; measured number inside the range.
By their numbers in this assay, from the lowest: compounds 3, 1 and 2 (each within the scatter of the next, the first and the last beyond it).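

Within the data shown here, compounds 1 and 3 give the first measured exchange at this position in this assay: on a saturated chain carbon, three bonds along the chain from an amide-type nitrogen and a carbonyl carbon, methylsulfanyl in place of the group of 5 heavy atoms gives a number 3.1 percentage points lower from compound 1 to compound 3 (within the scatter). The exchange takes the count from 3 hydrogen-bond donors to 0 and the group from 5 heavy atoms to 2, yet the read-out at this dose and time does not separate the two compounds. For this one pair, then, neither the loss of the donors nor the smaller group leaves a mark beyond the scatter. Nothing measured here bears on why the two side chains read alike.

Going by these compounds, it remains open whether any group at this place can lift the read-out clear of the scatter, and an amine, a hydroxyl or a longer chain would test that in this assay. A single pair at one dose and one time also leaves open whether the same holds at a higher dose or at another time.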